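The source may report more compounds than this note shows. Statements on the series, on what has been measured and on what is new or still open speak of the compounds shown alone.

Three compounds that share one core and differ in a single group on an aromatic carbon have been tested in a functional assay on brain (Rattus norvegicus, strain Wistar) for inhibition; a lower number here means a stronger inhibitor, a higher number a weaker inhibitor. Compound 1 `Cc1[nH]c(=O)n(C2CCCCC2)c1-c1ccc(OCCC(C)C)cc1` gives 7200 nM, compound 2 `Cc1[nH]c(=O)n(C2CCCCC2)c1-c1ccc(C2CCCCC2)cc1` gives 28900 nM, and compound 3 `CCCCCCCc1ccc(-c2c(C)[nH]c(=O)n2C2CCCCC2)cc1` gives 8700 nM. Compound 3 therefore sits level with compound 1, while compound 2 is the weakest inhibitor of the three.

The next compound is compound 4 `Cc1[nH]c(=O)n(C2CCCCC2)c1-c1ccc(OCc2ccccc2)cc1`, with benzyloxy in place of heptyl on an aromatic carbon. The closest guide is the change from isopentyloxy to heptyl, a 1.2-fold higher number from compound 1 to compound 3 (0.08 log units; within the scatter), which lies within the scatter. Like compound 1, compound 4 has an oxygen-linked group, so a large change seems unlikely. Its group also contains a ring, however, and compound 2 offers a caution: cyclohexyl gave a 4.0-fold higher number from compound 1 to compound 2 (0.60 log units; beyond the scatter), and replacing it with heptyl gave a 3.3-fold lower number from compound 2 to compound 3 (0.52 log units; beyond the scatter). Both steps are modest, and neither group matches benzyloxy. In this assay, no step beyond the scatter is therefore expected, though a higher number is the likelier risk. The expected change is a 1.1-fold higher number from compound 3 to compound 4 (0.06 log units; within the scatter). Compound 4 is estimated at 10000 nM, within an expected range of 4000 nM to 25000 nM.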

Compound 4, half-maximal inhibitory concentration: 8300 nM
The estimate for compound 4 lay 1.2-fold (0.08 log units) above the measured number; measured number inside the range.
By their numbers in this assay, from the lowest: compounds 1, 4 and 3 (each within the scatter of the next); then compound 2.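

In this assay, a group that carries an aromatic ring fits at this position as well as the open chains do: benzyloxy in place of heptyl gives little change (a 1.0-fold lower number from compound 3 to compound 4 (0.02 log units; within the scatter)), and so does phenyl in place of isobutyl at the end of the oxygen-linked chain (a 1.2-fold higher number from compound 1 to compound 4 (0.06 log units; within the scatter)). A ring in the group therefore does not by itself bring the higher number seen with compound 2, as benzyloxy in place of cyclohexyl shows (a 3.5-fold lower number from compound 2 to compound 4 (0.54 log units; beyond the scatter)). Nothing measured here explains why compound 2 stands apart from the other three.

Going by these compounds, whether an amine, a carboxylic acid or a much shorter chain at this position would stay at this level remains open. So does whether a phenyl group set directly on the aromatic ring would behave like cyclohexyl or like benzyloxy.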